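The source may report more compounds than this note shows. Statements on the series, on what has been measured and on what is new or still open speak of the compounds shown alone.

In a functional assay on MCF7 cells (Homo sapiens) for antiproliferative activity, read by MTT assay, with a stated time of 48 h (a lower number here means a stronger inhibitor, a higher number a weaker inhibitor), three compounds sharing one core have been measured, and they differ only in the group on a double-bonded ring carbon. Compound 1 (`COC/C1=C/C[C@](C)(CCC=C(C)C)/C=C/[C@@H](OC(=O)C=C(C)C)[C@](C)(O)/C=C/C1=O`), with methoxymethyl, gives 4130 nM. Compound 2 (`CC(C)=CCC[C@]1(C)/C=C/[C@@H](OC(=O)C=C(C)C)[C@](C)(O)/C=C/C(=O)/C(C=O)=C\C1`), with formyl, gives 12600 nM. Compound 3 (`CC(C)=CCC[C@]1(C)/C=C/[C@@H](OC(=O)C=C(C)C)[C@](C)(O)/C=C/C(=O)/C(CCl)=C\C1`), with chloromethyl, gives 610 nM, the lowest of the three numbers.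

Compound 4 (`CC(C)=CCC[C@]1(C)/C=C/[C@@H](OC(=O)C=C(C)C)[C@](C)(O)/C=C/C(=O)/C(CN(C)C)=C\C1`) has not yet been measured. Its difference from compound 3 is dimethylamino in place of chloro on a saturated chain carbon bound to a double-bonded ring carbon.

Within the data shown here, no measured compound carries dimethylamino, so the evidence is indirect. The nearest case is the exchange between methoxy and chloro at the same place, which gave a 6.8-fold lower number from compound 1 to compound 3 (0.83 log units; beyond the scatter). The step of a 21-fold lower number from compound 2 to compound 3 (1.32 log units; beyond the scatter) is large, but it involves formyl, and a 3.1-fold higher number from compound 1 to compound 2 (0.48 log units; beyond the scatter) separates the two compounds without chloro. Both of these compounds stand higher than compound 3, and none of the three goes against that.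

Losing the chloro is therefore expected to raise the number in this assay by a modest amount, close to the size of the step from compound 1. The expected step is a 4.9-fold higher number from compound 3 to compound 4 (0.69 log units; beyond the scatter). Compound 4 is expected at 3000 nM, within an estimated range of 900 nM to 10000 nM.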

Compound 4, half-maximal inhibitory concentration: 690 nM
Compound 4: middle estimate off by 4.3-fold (0.64 log units), on the high side, outside the stated range (below it).
By their numbers in this assay, from the lowest: compounds 3 and 4 (each within the scatter of the next); then compound 1; then compound 2.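

In this assay, dimethylamino and chloro on a saturated chain carbon bound to a double-bonded ring carbon leave the number level, a 1.1-fold higher number from compound 3 to compound 4 (0.05 log units; within the scatter), so among these compounds a low number at this place is not tied to chloro. The earlier compounds shown here offered only methoxy and formyl as alternatives, and both stood higher; dimethylamino now separates itself from methoxy on the same carbon, a 6.0-fold lower number from compound 1 to compound 4 (0.78 log units; beyond the scatter), and (dimethylamino)methyl separates itself from formyl on the double-bonded ring carbon, an 18-fold lower number from compound 2 to compound 4 (1.26 log units; beyond the scatter). Chloro therefore no longer stands alone at the low end of the series, and the two groups that share that end differ in both name and heavy atoms.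

On these data alone, whether a cyclic amine such as morpholine, a primary amine or a hydroxyl group on the same carbon would stay level with compound 3 and compound 4, or move towards compound 1, remains open. Nothing available accounts for why dimethylamino matches chloro in this assay while methoxy does not.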